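Trimming the amino acid side chain of a purine acetamide

This account rests on a few compounds, and the source may have more. Where it says the series, first, only, none or still open, it means among the compounds named here.

compound 1, `O=C(O)[C@@H]1CCCN1C(=O)CN(c1nc(Cl)nc2[nH]cnc12)C1CC1`: 26%
compound 2, `O=C(O)CNC(=O)CN(c1nc(Cl)nc2[nH]cnc12)C1CC1`: 32.3%
compound 3, `CC(C)C[C@H](NC(=O)CN(c1nc(Cl)nc2[nH]cnc12)C1CC1)C(=O)O`: 27%

Three compounds share one core and differ only in the amino acid joined through the amide. In a functional assay on the whole organism (Tail, strain ICR) with Mus musculus as the target, in the tail flick test, with a stated time of 90 min, at a dose of 25 umol/kg by the oral route (on this read-out higher numbers stand for a stronger effect at the one dose given and lower numbers for a weaker effect), compound 1 gives 26%, compound 2 gives 32.3% and compound 3 gives 27%. The two single changes among them left little trace: a number 6.3 percentage points higher from compound 1 to compound 2 (within the scatter), and a number 5.3 percentage points lower from compound 2 to compound 3 (within the scatter). Compound 3 thus stands second highest of the three numbers, with compound 1 its nearest neighbour and compound 2 its furthest, and all three values lie within the usual scatter of one another.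

Compound 4, `C[C@H](NC(=O)CN(c1nc(Cl)nc2[nH]cnc12)C1CC1)C(=O)O`, continues the series at the same place. The change from compound 3 is hydrogen in place of isopropyl on a saturated chain carbon, two bonds along the chain from an amide-type nitrogen and a carbonyl carbon, which, cut one bond further out, reads isobutyl to methyl. The step that bears on it is the one that put the isobutyl in, a number 5.3 percentage points lower from compound 2 to compound 3 (within the scatter), and that step stayed within the scatter; the earlier step around the amide, a number 6.3 percentage points higher from compound 1 to compound 2 (within the scatter), did likewise. Compound 4 is therefore expected to show a number 2 percentage points higher from compound 3 to compound 4 (within the scatter), no movement beyond the scatter. Compound 4 is estimated at 29%, with a range from 18% to 40%.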

Compound 4, a percentage reported as activity, at one dose (the size of the read-out at that dose, not a potency): 43.5%
For compound 4 the middle estimate is 14.5 percentage points below the measured one; measured number above the stated range.
By their numbers in this assay, from the lowest: compounds 1, 3 and 2 (each within the scatter of the next); then compound 4.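

Methyl on the saturated chain carbon bound to an amide-type nitrogen and a carbonyl carbon is the first change at this position to move the number beyond the scatter in this assay, with a number 11.2 percentage points higher from compound 2 to compound 4 (beyond the scatter) in the comparison with hydrogen, whereas isobutyl at the same place gave a number 5.3 percentage points lower from compound 2 to compound 3 (within the scatter) and stayed within it. Cutting isobutyl back to methyl gives a number 16.5 percentage points higher from compound 3 to compound 4 (beyond the scatter) at the same reading, and putting (1-carboxyethyl)amino in place of 2-carboxypyrrolidin-1-yl on the carbonyl carbon gives a number 17.5 percentage points higher from compound 1 to compound 4 (beyond the scatter) as its result. The number therefore does not follow the size of the group in a steady line, since methyl stands beyond the scatter above both hydrogen and isobutyl, and compound 4 is the highest of the four.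

Nothing available here accounts for this rise. From the compounds shown here alone, whether the peak belongs to methyl alone stays open, as ethyl or isopropyl on that carbon would be needed to show how far it extends, and a longer chain ending in an amine would test the same position in another way.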